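The source may report more compounds than this note shows. Statements on the series, on what has been measured and on what is new or still open speak of the compounds shown alone.

Measured so far:
compound 1, `OCCCCC(F)F` — 0.66
compound 2, `CCC(F)(F)CO` — 0.67
compound 3, `OCCCCCF` — 0.52

All three numbers come from a physicochemical assay for lipophilicity, read by NMR; on this read-out lower numbers stand for lower lipophilicity and higher numbers for higher lipophilicity. Compound 1 and compound 3 differ in one place: hydrogen in place of fluoro on a saturated chain carbon bound to a fluorine atom and a saturated chain carbon. This step gave a number 0.14 log units lower from compound 1 to compound 3 (within the scatter). In this assay compound 2 sits close to both compound 1 and compound 3, with every gap among the three inside the usual scatter. The difference between the cores of compound 1 and compound 2 is not broken down here.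

Compound 4, `CCC(F)CO`, is still unmeasured. It arises from compound 2 by the same kind of change: hydrogen in place of fluoro on a saturated chain carbon bound to a fluorine atom and two saturated chain carbons. The surroundings are not identical, though: in compound 1 the carbon in question is bound to a fluorine atom and a saturated chain carbon, in compound 2 to a fluorine atom and two saturated chain carbons.

A step of about a number 0.14 log units lower from compound 2 to compound 4 (within the scatter) in this assay is expected. That expectation rests on the single measured case of this kind of change, which showed a number 0.14 log units lower from compound 1 to compound 3 (within the scatter), a step too small to separate from scatter. For compound 4 in this assay a value of 0.53 is estimated, with the likely range running from 0.3 to 0.76.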

Compound 4, partition coefficient: 0.26
Compound 4: the middle estimate sits 0.27 log units above what was measured; measured number outside the range, below it.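

In this assay, putting hydrogen in place of fluoro on a saturated chain carbon bound to a fluorine atom and two saturated chain carbons gave a number 0.41 log units lower from compound 2 to compound 4 (beyond the scatter) on this core, while the same kind of change on the core of compound 1 gave a number 0.14 log units lower from compound 1 to compound 3 (within the scatter) and so stayed inside the scatter. The size of the step therefore did not carry over from one core to the other, but a single pair on each core cannot show whether the core itself or the surroundings of that carbon set the size. Nothing shown here gives a reason for the difference between the two steps.

Going by these compounds, it remains open whether the change would give a similar step on a core with an amine or a carboxylic acid in place of the hydroxyl group, or on a longer chain. Going by these compounds alone, with only two pairs, no general rule for this change can yet be stated for the series.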